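The source may hold more compounds than are shown below. What is called first, only, known or untested is meant among the compounds shown, and "the series" means these compounds.

Compound 1 `O=C(Nc1cc(C(F)(F)F)cc(C(F)(F)F)c1)C1CCc2ccccc2N1C(=O)c1ccccc1Cl` gives 4050 nM in a functional assay on HCT-15 cells (Homo sapiens) for cytotoxicity, read by sulforhodamine B assay, with a stated time of 72 h; a higher number here means a weaker inhibitor of growth, a lower number a stronger inhibitor of growth. Compound 2 `O=C(Nc1ccccc1O)C1CCc2ccccc2N1C(=O)c1ccccc1Cl` gives 44900 nM in this assay. Compound 3 `CC(=O)N1c2ccccc2CCC1C(=O)Nc1cc(C(F)(F)F)cc(C(F)(F)F)c1` in this assay returns > 70000 nM, which is a limit of the assay rather than a number (the limit of > 70000 nM in this assay, at which 1 of the 3 values shown sits). Among the compounds with values here, the one measured step that reaches compound 3 is an at least 17-fold higher number from compound 1 to compound 3 (1.23 log units; beyond the scatter), so compound 3 sits far below compound 1. Compound 4 `CCCC(=O)N1c2ccccc2CCC1C(=O)Nc1cc(C(F)(F)F)cc(C(F)(F)F)c1` differs from compound 3 by ethyl in place of hydrogen on a saturated chain carbon bound to a carbonyl carbon. Within the data shown here, no measured step tests a chain extension on this carbonyl, and the only step into compound 3 was large, so a modest gain at most is expected, likely leaving compound 4 near or at the limit. For compound 4 in this assay the estimate is 50000 nM, between 15000 nM and 150000 nM. The expected step is an at least 1.4-fold lower number from compound 3 to compound 4 (0.14 log units; that floor lies within the scatter).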

Compound 4, concentration for 50% growth inhibition: 21900 nM
Compound 4: the middle estimate sits 2.3-fold (0.36 log units) above what was measured; measured number inside the range.
By their numbers in this assay, from the lowest: compound 1; then compound 4; then compound 2. At a limit, above all of these: compound 3.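

Going from methyl to propyl on this carbonyl moves the series off the limit in this assay, with an at least 3.1-fold lower number from compound 3 to compound 4 (0.50 log units; beyond the scatter), so a saturated chain at this place does change growth inhibition. Propyl still falls short of 2-chlorophenyl on a carbonyl carbon, with a 5.4-fold higher number from compound 1 to compound 4 (0.73 log units; beyond the scatter). The first of these steps is only a floor, since the value of compound 3 is a limit: the limit of > 70000 nM in this assay, at which 1 of the 4 values shown sits.

Still open, from the compounds shown here alone, is whether a longer chain such as hexyl, or a branched one such as isopropyl, would close the remaining gap to compound 1. An unsubstituted phenyl on this carbonyl would show how much of that gap depends on the chlorine.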